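The source may hold more compounds than are shown below. What is called first, only, known or untested is meant among the compounds shown, and "the series" means these compounds.

Three compounds have been measured in a functional assay on MCF7 cells (Homo sapiens) for antiproliferative activity; on this read-out higher numbers stand for weaker inhibition and lower numbers for stronger inhibition:

Compound 1, `COc1c(C(/C=C(\C)N2CCCC2)=C2C(=O)c3ccccc3C2=O)c(O)cc2occc12`, gives 15.5 ug/mL.
Compound 2, `COc1c(C(/C=C(\C)N2CCCC2)=C2C(=O)c3ccccc3C2=O)c(O)c(OC)c2occc12`, gives 13.2 ug/mL.
Compound 3, `COc1c2c(cc3occc13)OC1(CCCCC1)c1snnc1-2`, gives 15.9 ug/mL.

Compound 1 and compound 2 share a core and differ only by methoxy in place of hydrogen on an aromatic carbon; this change gave a 1.2-fold lower number from compound 1 to compound 2 (0.07 log units; within the scatter). Compound 3 has a different core, and the difference between the two cores is not broken down here. Its number lies close to those of compound 1 and compound 2, all within the scatter of one another.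

Compound 4, `COc1c2c(c(OC)c3occc13)OC1(CCCCC1)c1snnc1-2`, has not yet been measured. It differs from compound 3 by methoxy in place of hydrogen on an aromatic carbon. This is the same kind of change as that between compound 1 and compound 2, though the surroundings differ: in compound 2 the methoxy sits on a ring in a fused or bridged system of two rings, ortho to a fused ring, ortho to a hydroxy group, meta to a fused ring and meta to a large group, whereas in compound 4 it sits on a ring in a fused or bridged system of five rings, ortho to two fused rings and meta to two fused rings; in both it is para to a methoxy group. Because a 1.2-fold lower number from compound 1 to compound 2 (0.07 log units; within the scatter) stayed within the scatter, a similarly small step is expected for compound 4, a 1.2-fold lower number from compound 3 to compound 4 (0.07 log units; within the scatter). In this assay compound 4 is estimated at 13.5 ug/mL, most likely between 7 ug/mL and 28 ug/mL.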

Compound 4, half-maximal inhibitory concentration: 14.9 ug/mL
Compound 4: middle estimate off by 1.1-fold (0.04 log units), on the low side, and the stated range covers the measured number.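

In this assay, methoxy in place of hydrogen on an aromatic carbon gave a 1.1-fold lower number from compound 3 to compound 4 (0.03 log units; within the scatter). Set beside the earlier step, the same change looks alike on the two cores, and no difference between them can be told from the scatter: the same change on two cores in this assay, a 1.2-fold lower number (0.07 log units; within the scatter) from compound 1 to compound 2 and a 1.1-fold lower number (0.03 log units; within the scatter) from compound 3 to compound 4, 1.1-fold (0.04 log units) apart, within the scatter of two such steps. This shows that, on these two cores, the change left the number within the scatter each time; it does not show that methoxy has any real effect in this assay, and it does not show that a step of clear size would carry from one core to the other, since neither step here stands clear of the scatter.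

The compounds shown leave open whether another group on this aromatic carbon, such as an amine, a carboxylic acid or a longer chain like butoxy, would give a step beyond the scatter on either core. They also leave open whether the match between the two steps would hold on a third core.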